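This account rests on a few compounds, and the source may have more. Where it says the series, first, only, none or still open, it means among the compounds named here.

Compound 1, `CSc1ncnc2c1c(-c1ccccc1)cn2[C@@H]1O[C@H](CO)[C@@H](O)[C@H]1O`, gives > 20000 nM in a functional assay on HL-60 cells (Homo sapiens) for antiproliferative activity, read by XTT assay, with a stated time of 72 h (a lower number here means a stronger inhibitor, a higher number a weaker inhibitor), which is a limit of that assay and not a number.
Compound 2, `COc1ncnc2c1c(-c1ccccc1)cn2[C@@H]1O[C@H](CO)[C@@H](O)[C@H]1O`, gives > 20000 nM in this assay, again a limit rather than a number.
Compound 3, `CNc1ncnc2c1c(-c1ccccc1)cn2[C@@H]1O[C@H](CO)[C@@H](O)[C@H]1O`, gives > 20000 nM in this assay, also a limit.

Compound 2 therefore stands at the limit of this assay, and the two further values shown are limits as well, so no order among the three compounds can be read. The steps a step that the two limits leave unreadable from compound 1 to compound 2, a step that the two limits leave unreadable from compound 1 to compound 3 and a step that the two limits leave unreadable from compound 2 to compound 3 are accordingly unreadable, since all three values sit at the limit of > 20000 nM in this assay, at which 3 of the 3 values shown sit. Compound 4, `COc1ncnc2c1c(-c1ccco1)cn2[C@@H]1O[C@H](CO)[C@@H](O)[C@H]1O`, differs from compound 2 by furan-2-yl in place of phenyl on an aromatic carbon. Within the data shown here, no measured step alters this group, so none bears directly on the change; the measured steps show only that methylsulfanyl, methoxy and methylamino on an aromatic carbon all leave the value at the limit. The step that the limit leaves unreadable from compound 2 to compound 4 is therefore expected to remain unreadable, with compound 4 most likely reported once more as a limit. For compound 4 an estimate of 30000 nM, within 10000 nM to 100000 nM, is expected.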

Compound 4, half-maximal inhibitory concentration: 100 nM
For compound 4 the middle estimate is 300-fold (2.48 log units) above the measured one; the measured number lies below the stated range.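

In this assay, the aromatic carbon of the five-membered aromatic ring with 1 nitrogen proves to be a place where a change can be read: furan-2-yl in place of phenyl gives an at least 200-fold lower number from compound 2 to compound 4 (2.30 log units; beyond the scatter). That size is only a lower bound, as the value of compound 2 is a limit of the assay and not a number. The earlier steps, which changed another group while phenyl stayed in place, cannot be read, and none of those compounds gave a measurable value: the limit of > 20000 nM in this assay, at which 3 of the 4 values shown sit.

From the compounds shown here alone, it remains open whether the gain belongs to furan-2-yl alone or would also appear with thiophen-2-yl or furan-3-yl at this carbon. Also open, going by these compounds, is whether furan-2-yl keeps this value with methylsulfanyl, methylamino or a plain amine in place of methoxy.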